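The source may report more compounds than this note shows. Statements on the series, on what has been measured and on what is new or still open speak of the compounds shown alone.

Going by the values given here, compound 3 `COc1ccccc1C(=O)NCCNc1cccc(NS(=O)(=O)c2cc(-c3cccc(C(=O)N4CCC4)c3)ccc2OC)c1` gives 235 nM in an assay on CHO-K1 cells for agonist activity at Orexin receptor type 2 (Homo sapiens), read by a luciferase reporter (a higher number here means that more compound is needed for the effect, a lower number that less compound is needed), the lower of the two numbers measured so far. Compound 1 `COc1cccc(-c2ccc(OC)c(S(=O)(=O)Nc3cccc(NCCNC(=O)c4ccccc4OC)c3)c2)c1` gives 800 nM in this assay, and a 3.4-fold lower number from compound 1 to compound 3 (0.53 log units; beyond the scatter). Compound 2 `COC(=O)c1cccc(-c2ccc(OC)c(S(=O)(=O)Nc3cccc(NCCNC(=O)c4ccccc4OC)c3)c2)c1` reaches only a limit in this assay, > 10000 nM. Compound 4 `COc1ccccc1C(=O)NCCNc1cccc(NS(=O)(=O)c2cc(-c3cccnc3)ccc2OC)c1` differs from compound 3 in one place: pyridin-3-yl in place of 3-((azetidin-1-yl)carbonyl)phenyl on an aromatic carbon. Among the compounds with values here, no measured step exchanges the whole substituted phenyl for a heteroaryl ring; the steps that bear on it all concern the substituent at that same position: a 3.4-fold lower number from compound 1 to compound 3 (0.53 log units; beyond the scatter), whereas an at least 12-fold higher number from compound 1 to compound 2 (1.09 log units; beyond the scatter) and an at least 42-fold lower number from compound 2 to compound 3 (1.62 log units; beyond the scatter). The pyridin-3-yl of compound 4 carries neither the methoxy of compound 1 nor a carbonyl group, so the gain seen in compound 3 is not expected to carry over, and a number closer to that of compound 1, possibly higher, is the working expectation. For compound 4 a value of 1500 nM in this assay is estimated, within 400 nM to 6000 nM. The expected step is a 6.4-fold higher number from compound 3 to compound 4 (0.81 log units; beyond the scatter).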

Compound 4, half-maximal effective concentration: 268 nM
Estimate against measurement, compound 4: 5.6-fold (0.75 log units) above, outside the stated range (below it).
By their numbers in this assay, from the lowest: compounds 3 and 4 (each within the scatter of the next); then compound 1. At a limit, above all of these: compound 2.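

Pyridin-3-yl, with fewer heavy atoms than the 3-((azetidin-1-yl)carbonyl)phenyl, cannot be told apart from that group at this position: a 1.1-fold higher number from compound 3 to compound 4 (0.06 log units; within the scatter). Neither a substituted phenyl nor a carbonyl group is therefore required at this position to reach the level of compound 3, and the heteroaryl ring also compares well with the 3-methoxyphenyl: a 3.0-fold lower number from compound 1 to compound 4 (0.47 log units; beyond the scatter). Compound 2 gives a limit and not a number, so an at least 37-fold lower number from compound 2 to compound 4 (1.57 log units; beyond the scatter) is a bound only, and its 3-(methoxycarbonyl)phenyl is the one group shown that goes with such a limit: the limit of > 10000 nM in this assay, at which 1 of the 4 values shown sits.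

Going by these compounds, whether the ring nitrogen of pyridin-3-yl itself counts remains open, and an unsubstituted phenyl or a pyridin-4-yl at this position would test it. Also open, on these data alone, is whether the limit belongs to the ester as such, which a carboxylic acid or a primary amide in its place would help to separate.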